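From Propylamino to Benzylamino on the Shared Core

The source may report more compounds than this note shows. Statements on the series, on what has been measured and on what is new or still open speak of the compounds shown alone.

In a functional assay on the whole organism with Rattus norvegicus as the target (on this read-out higher numbers stand for an effect only at larger amounts of compound and lower numbers for an effect already at smaller amounts), compound 1 `COc1cc(N(C)C)c(Cl)cc1C(=O)NC1CCN(Cc2ccccc2)C1` gives 0.12 mg/kg and compound 2 `CCNc1cc(OC)c(C(=O)NC2CCN(Cc3ccccc3)C2)cc1Cl` gives 0.1 mg/kg, while compound 3 `CCCNc1cc(OC)c(C(=O)NC2CCN(Cc3ccccc3)C2)cc1Cl` stands highest of the three at 17 mg/kg on this scale. Compound 4 `COc1cc(NCc2ccccc2)c(Cl)cc1C(=O)NC1CCN(Cc2ccccc2)C1` differs from compound 3 in one place phenyl in place of ethyl on a saturated chain carbon bound to a nitrogen on an aromatic ring with phenyl in place of ethyl on a saturated chain carbon bound to a nitrogen on an aromatic ring, turning propylamino into benzylamino. The large steps of a 170-fold higher number from compound 2 to compound 3 (2.23 log units; beyond the scatter) and a 140-fold higher number from compound 1 to compound 3 (2.15 log units; beyond the scatter) both end at the propylamino compound, whereas a 1.2-fold lower number from compound 1 to compound 2 (0.08 log units; within the scatter) stays within the scatter. Among the compounds with values here, no measured compound carries a benzylamino group, so no return toward the lower numbers is assumed. The expected change in this assay is a 1.1-fold lower number from compound 3 to compound 4 (0.05 log units; within the scatter) and thus no step beyond the scatter. For compound 4 the estimated value is 15 mg/kg with an expected range from 1.5 mg/kg up to 80 mg/kg at the upper end.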

Compound 4, dose for half-maximal effect: > 30 mg/kg
Compound 4: only a limit was reported; the forecaster's own chance of this, stated with the estimate: 20%; middle value at least 2.0-fold (0.30 log units) from the limit.
By their numbers in this assay, from the lowest: compounds 2 and 1 (each within the scatter of the next); then compound 3. At a limit, above all of these: compound 4.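

Compound 4 is reported in this assay only as a limit: the limit of > 30 mg/kg in this assay, at which 1 of the 4 values shown sits.
Read against propylamino, the result is an at least 1.7-fold higher number from compound 3 to compound 4 (0.24 log units; that floor lies within the scatter), so the two groups cannot be ordered, but benzylamino brings no return toward the low numbers. The high range therefore extends from a saturated chain to one ending in phenyl, as an at least 300-fold higher number from compound 2 to compound 4 (2.47 log units; beyond the scatter) and an at least 250-fold higher number from compound 1 to compound 4 (2.39 log units; beyond the scatter) show.

On these data alone, how far above its limit compound 4 lies stays open. So does whether a plain amino group or a butylamino chain would fall with the low pair or the high pair.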